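The compounds below may be only part of what the source reports. "The series", "measured", "known", "first", "only" and "open" are said of these compounds alone.

Measured so far:
compound 1 `CC(C)(C)c1ccc(NC(=O)N2CCCN(C(=O)c3ccc(C(F)(F)F)cc3)CC2)cc1` — in an in vitro ADME assay on microsomes from liver (Homo sapiens) for metabolic stability, read by LC-MS (a lower number here means that the compound disappears faster, a higher number that the compound lasts longer), compound 1 gives 0.0667 h
compound 2 `CN(C)c1ccc(C(=O)N2CCCN(C(=O)Nc3ccc(C(C)(C)C)cc3)CC2)cc1` — in this assay compound 2 gives 0.0667 h

For the measured compounds named here, compound 2 stands level with compound 1 in this assay: the one recorded step, no change at the digits printed from compound 1 to compound 2 (within the scatter), is within the scatter, so the two aryl substituents on the benzoyl carbonyl are indistinguishable on half-life here.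

The next compound, compound 3 `CC(C)(C)c1ccc(NC(=O)N2CCCN(C(=O)C3CCOCC3)CC2)cc1`, has not yet been run in this assay. It differs from compound 2 in one place: oxan-4-yl in place of 4-(dimethylamino)phenyl on a carbonyl carbon. Going by the values given here, this takes the benzoyl arene away altogether, which no measured step covers; the only step in hand swaps one aromatic substituent for another and left the half-life unchanged. There is therefore no measured basis for a directional move, and the expectation for this assay is a step of a 1.0-fold higher number from compound 2 to compound 3 (0.02 log units; within the scatter), i.e. none beyond the scatter, with the range widened for the untested change of ring type.

Compound 3 is estimated to give about 0.07 h in this assay, expected between 0.035 h and 0.2 h.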

Compound 3, half-life: 0.183 h
Compound 3: middle estimate off by 2.6-fold (0.42 log units), on the low side; measured number inside the range.
By their numbers in this assay, from the lowest: compounds 1 and 2 (each within the scatter of the next); then compound 3.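

At the carbonyl carbon whose other neighbour is the amide-type nitrogen in a ring, the aryl substituent exchange left the half-life unmoved, whereas removing the aromatic ring does move it in this assay: oxan-4-yl in place of 4-(dimethylamino)phenyl gives a 2.7-fold higher number from compound 2 to compound 3 (0.44 log units; beyond the scatter) and oxan-4-yl in place of 4-(trifluoromethyl)phenyl gives a 2.7-fold higher number from compound 1 to compound 3 (0.44 log units; beyond the scatter) with the same sign and size. Among these three compounds, the outcome therefore follows the exchange of the aromatic ring for oxan-4-yl and not the identity of the aryl substituent that leaves, and neither aryl compound goes against this. Nothing shown bears on why the half-life differs between the aryl compounds and the oxan-4-yl compound.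

For the compounds shown here, the single exchange removes aromaticity, reduces the heavy-atom count and brings in a ring oxygen together, so these compounds cannot separate the three, and a cyclohexyl group or a piperidin-4-yl amine at the same carbonyl carbon would be needed to do so. Also open, as far as these compounds go, is whether the step carries over to an open alkyl chain at this place, or to analogues in which the tert-butyl group on the other side of the core is replaced.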